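Removing a carbamoylmethyl group on a carboxylic acid analogue

The source may report more compounds than this note shows. Statements on the series, on what has been measured and on what is new or still open speak of the compounds shown alone.

Measured so far:
compound 1 `C[C@H](NC(=O)CN(c1nc(Cl)nc2[nH]cnc12)C1CC1)C(=O)OCc1ccccc1`, 41.2%
compound 2 `NC(=O)CC[C@H](NC(=O)CN(c1nc(Cl)nc2[nH]cnc12)C1CC1)C(=O)OCc1ccccc1`, 30.8%
compound 3 `NC(=O)CC[C@H](NC(=O)CN(c1nc(Cl)nc2[nH]cnc12)C1CC1)C(=O)O`, 33.1%

All three compounds were tested in a functional assay on the whole organism (Tail, strain ICR) with Mus musculus as the target, in the tail flick test, with a stated time of 30 min, at a dose of 25 umol/kg by the oral route; on this read-out higher numbers stand for a stronger effect at the one dose given and lower numbers for a weaker effect. Compound 1 is compound 2 with hydrogen in place of carbamoylmethyl on a saturated chain carbon, two bonds along the chain from an amide-type nitrogen and a carbonyl carbon, and this step gave a number 10.4 percentage points higher from compound 2 to compound 1 (beyond the scatter). Compound 3 differs from compound 2 in its core by hydrogen in place of benzyl on an oxygen next to a carbonyl group, a step of a number 2.3 percentage points higher from compound 2 to compound 3 (within the scatter).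

Compound 4 `C[C@H](NC(=O)CN(c1nc(Cl)nc2[nH]cnc12)C1CC1)C(=O)O` is not yet measured. It is compound 3 with hydrogen in place of carbamoylmethyl on a saturated chain carbon, two bonds along the chain from an amide-type nitrogen and a carbonyl carbon, the same change as that from compound 2 to compound 1, at the same place. Because that earlier step gave a number 10.4 percentage points higher from compound 2 to compound 1 (beyond the scatter), a similar gain is expected here, namely a number 8.9 percentage points higher from compound 3 to compound 4 (within the scatter), although a single prior example gives this only modest weight. Compound 4 is therefore estimated at 42%, with a plausible range from 30% to 55%.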

Compound 4, a percentage reported as activity, at one dose (the size of the read-out at that dose, not a potency): 48.1%
Compound 4: the middle estimate sits 6.1 percentage points below what was measured; measured number inside the range.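

Swapping carbamoylmethyl for hydrogen gave a number 15 percentage points higher from compound 3 to compound 4 (beyond the scatter), and this step agrees with the earlier one: the same change on two cores in this assay, a number 10.4 percentage points higher (beyond the scatter) from compound 2 to compound 1 and a number 15 percentage points higher (beyond the scatter) from compound 3 to compound 4, 4.6 percentage points apart, within the scatter of two such steps. Swapping benzyl for hydrogen on an oxygen next to a carbonyl group gave a number 6.9 percentage points higher from compound 1 to compound 4 (within the scatter), which also agrees with its earlier counterpart: the same change on two cores in this assay, a number 2.3 percentage points higher (within the scatter) from compound 2 to compound 3 and a number 6.9 percentage points higher (within the scatter) from compound 1 to compound 4, 4.6 percentage points apart, within the scatter of two such steps. In these four compounds, each change therefore carried over from one core to the other, but two examples of each on closely related cores do not show that it would carry over to any other core, and readings at one dose are not a measure of potency.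

As far as these compounds go, it remains open how other groups on that saturated chain carbon would compare with methyl, such as an ethyl chain, an amine or a carboxylic acid.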